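A few compounds are considered here, and "the series" means these few. Any claim that something is new, unique, unknown or untested is made for them only; others in the source may bear on it.

Working notes on a set of four bis-benzylidene piperidinone sulfonamides sharing one core, measured in a functional assay on SMMC-7721 cells (Homo sapiens) for cytotoxicity, read by MTT assay, with a stated time of 24 h; a lower number here means a stronger inhibitor, a higher number a weaker inhibitor.

Compound 1 `O=C1/C(=C/c2cccnc2)CN(S(=O)(=O)c2ccc([N+](=O)[O-])cc2)C/C1=C\c1ccccc1F` gives > 20000 nM in this assay, which is a limit of the assay and not a number (the limit of > 20000 nM in this assay, at which 1 of the 3 values shown sits). Compound 2 `O=C1/C(=C/c2cccnc2)CN(S(=O)(=O)c2ccc(C(F)(F)F)cc2)C/C1=C\c1ccccc1F` gives 7900 nM in this assay. Compound 3 `O=C1/C(=C/c2cccnc2)CN(S(=O)(=O)c2ccc([N+](=O)[O-])cc2)C/C1=C\c1ccccc1C(F)(F)F` gives 15900 nM in this assay. Compound 4 `O=C1/C(=C/c2cccnc2)CN(S(=O)(=O)c2ccc(C(F)(F)F)cc2)C/C1=C\c1ccccc1C(F)(F)F` has not yet been measured.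

From compound 1 to compound 2 the change is trifluoromethyl in place of nitro on an aromatic carbon, and it makes a step of an at least 2.5-fold lower number from compound 1 to compound 2 (0.40 log units; beyond the scatter). The two cores differ as follows: trifluoromethyl in place of fluoro on an aromatic carbon, with a step of an at least 1.2-fold lower number from compound 1 to compound 3 (0.09 log units; that floor lies within the scatter). From compound 3 to compound 4 the same change is made on the other core: trifluoromethyl in place of nitro on an aromatic carbon.

For compound 4 a step of a 3.2-fold lower number from compound 3 to compound 4 (0.50 log units; beyond the scatter) is expected, resting on the step seen from compound 1 to compound 2 an at least 2.5-fold lower number from compound 1 to compound 2 (0.40 log units; beyond the scatter), whose true size is open because compound 1 sits at a limit (the limit of > 20000 nM in this assay, at which 1 of the 3 values shown sits). Compound 4 is therefore estimated at 5000 nM, expected to fall between 2000 nM and 12000 nM.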

Compound 4, half-maximal inhibitory concentration: 1730 nM
For compound 4 the middle estimate is 2.9-fold (0.46 log units) above the measured one; measured number outside the range, below it.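

In this assay, trifluoromethyl in place of nitro gives a 9.2-fold lower number from compound 3 to compound 4 (0.96 log units; beyond the scatter), so the change from 4-nitrophenyl to 4-(trifluoromethyl)phenyl lowers the number on both cores: the same change on two cores in this assay, an at least 2.5-fold lower number (0.40 log units; beyond the scatter) from compound 1 to compound 2 and a 9.2-fold lower number (0.96 log units; beyond the scatter) from compound 3 to compound 4; the limit leaves it open whether they differ

The other change, trifluoromethyl in place of fluoro on an aromatic carbon, gives a 4.6-fold lower number from compound 2 to compound 4 (0.66 log units; beyond the scatter), while its earlier step does not clear the scatter at its floor: the same change on two cores in this assay, an at least 1.2-fold lower number (0.09 log units; that floor lies within the scatter) from compound 1 to compound 3 and a 4.6-fold lower number (0.66 log units; beyond the scatter) from compound 2 to compound 4; the limit leaves it open whether they differ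

Compound 1 gives > 20000 nM, which is a limit of the assay and not a number, so the shared size of either step remains unshown, and two cores set no rule for the wider series.

Open, from the compounds shown here alone, is whether an amine or a carboxylic acid, in the place held by nitro and trifluoromethyl, would fit the same steps. Also open, going by these compounds, is how a chlorine or a methoxy group would compare with fluoro and trifluoromethyl on the shared core, and whether these steps hold in any other cell line.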